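This account rests on a few compounds, and the source may have more. Where it says the series, first, only, none or still open, it means among the compounds named here.

Measured in a functional assay on OVCAR-4 cells (Homo sapiens) for inhibition, read by sulforhodamine B assay, with a stated time of 48 h, tested at 10 uM; a higher number here means more inhibition at the concentration tested (going by the name of the read-out), a lower number less inhibition:
compound 1 `COc1ccc(-c2cn3ccnc3c(-c3ccc4ncn(C5CCCCC5)c4c3)n2)cc1` gives 46.4%.
compound 2 `COc1ccccc1-c1cn2ccnc2c(-c2ccc3ncn(C4CCCCC4)c3c2)n1` gives 13.2%.

Going by the values given here, compound 2 stands lowest of the two numbers in this assay; the one measured step, a number 33.2 percentage points lower from compound 1 to compound 2 (beyond the scatter), leads to it. Compound 3 `Fc1ccccc1-c1cn2ccnc2c(-c2ccc3ncn(C4CCCCC4)c3c2)n1` differs from compound 2 by fluoro in place of methoxy on an aromatic carbon. Among the compounds with values here, no measured step exchanges these two groups; the known step concerns where methoxy sits, not its replacement by fluoro, so it offers no direct guide. The step in this assay is therefore expected to stay within the scatter: a number 2.8 percentage points higher from compound 2 to compound 3 (within the scatter). Compound 3 is estimated at 16%, with a range from 0% to 40%.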

Compound 3, a percentage reported as inhibition, at one concentration (the size of the read-out at that concentration, not a potency): 4.51%
Beside the measured number, compound 3's estimate is 11.5 percentage points above it, within the range that was stated.
By their numbers in this assay, from the lowest: compounds 3 and 2 (each within the scatter of the next); then compound 1.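

On the aromatic carbon ortho to a large group, fluoro in place of methoxy gives a number 8.7 percentage points lower from compound 2 to compound 3 (within the scatter), so in this assay this exchange does not separate the two compounds. The 2-fluorophenyl group also stays well short of the 4-methoxyphenyl group, with a number 41.9 percentage points lower from compound 1 to compound 3 (beyond the scatter); that step changes both group and place, so it cannot be assigned to either alone. No evidence bearing on the cause of these differences is available. Open, going by these compounds, is whether 4-fluorophenyl matches 4-methoxyphenyl, and whether an amine on the same aromatic carbon departs from methoxy and fluoro.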